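Solubility notes on the shared core, compound 4 pending

This account rests on a few compounds, and the source may have more. Where it says the series, first, only, none or still open, it means among the compounds named here.

Compound 1 `CNC(=O)c1cccn(Cc2ccccc2)c1=O` in a physicochemical assay for solubility; on this read-out higher numbers stand for higher solubility and lower numbers for lower solubility: 78 ug/mL
Compound 2 `CNC(=O)c1cc(C(=O)NC2CC2)cn(Cc2ccc3nc[nH]c3c2)c1=O` in this assay : >= 163 ug/mL (a limit)
Compound 3 `CCNC(=O)c1cc(C(=O)NC)c(=O)n(Cc2ccccc2)c1` in this assay : >= 144 ug/mL (a limit)

Compound 2 in this assay is reported only as a limit, >= 163 ug/mL, so its standing among the shown numbers is a floor rather than a point (the limit of >= 163 ug/mL in this assay, at which 1 of the 3 values shown sits). Compound 3 is likewise reported as a limit (the limit of >= 144 ug/mL in this assay, at which 1 of the 3 values shown sits). Going by the values given here, the single measured step, an at least 1.8-fold higher number from compound 1 to compound 3 (0.26 log units; that floor lies within the scatter), concerns ethylcarbamoyl entering on an aromatic carbon, and its floor lies within the scatter; it does not touch the group that changes here.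

Compound 4 `CNC(=O)c1cc(C(=O)NC2CC2)cn(Cc2ccc(F)cc2)c1=O` differs from compound 2 by 4-fluorophenyl in place of 1H-benzimidazol-6-yl on a saturated chain carbon bound to an aromatic nitrogen. Among the compounds with values here, no measured step covers this exchange. What remains is compound 1, which carries a benzyl group and lacks the second carboxamide, and which gives 78 ug/mL in this assay. On that basis compound 4 is expected to land in the upper part of the measured range but not necessarily at the floor seen for compound 2. Compound 4 is therefore estimated at 100 ug/mL, between 40 ug/mL and 220 ug/mL. The expected step is an at least 1.6-fold lower number from compound 2 to compound 4 (0.21 log units; that floor lies within the scatter), a decrease of uncertain size given that the starting point is a limit.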

Compound 4, solubility: >= 162 ug/mL
Compound 4 was reported as a limit; the forecaster's own chance of this, stated with the estimate: 30%; at least 1.6-fold (0.20 log units) between middle value and limit.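

In this assay compound 4 is reported only as a limit, >= 162 ug/mL. Compound 2 is likewise only a limit, >= 163 ug/mL. No step can be read between compound 2 and compound 4. The compounds shown leave open whether 4-fluorophenyl in place of 1H-benzimidazol-6-yl changes this read-out at all, and in which direction.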